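Swapping the Aryl Group on a Shared Core

A few compounds are considered here, and "the series" means these few. Any claim that something is new, unique, unknown or untested is made for them only; others in the source may bear on it.

In a functional assay on BGC-823 cells (Homo sapiens) for cytotoxicity, read by CCK-8 assay, with a stated time of 72 h (on this read-out lower numbers stand for stronger inhibition and higher numbers for weaker inhibition), three compounds on a shared core have been measured:

compound 1 `C=CCn1c(=O)/c(=C\c2cccc(Cl)c2)[nH]c(=O)/c1=C\c1ccccc1OC`: 4600 nM
compound 2 `C=CCn1c(=O)/c(=C\c2cccc(Cl)c2Cl)[nH]c(=O)/c1=C\c1ccccc1OC`: 2200 nM
compound 3 `C=CCn1c(=O)/c(=C\c2ccccc2C(F)(F)F)[nH]c(=O)/c1=C\c1ccccc1OC`: 5100 nM

Compound 3 has the highest number of the three, though only just: a 1.1-fold higher number from compound 1 to compound 3 (0.04 log units; within the scatter) lies within the scatter, whereas a 2.3-fold higher number from compound 2 to compound 3 (0.37 log units; beyond the scatter) is a modest step beyond it. Compound 4 `C=CCn1c(=O)/c(=C\c2ccc(C)cc2)[nH]c(=O)/c1=C\c1ccccc1OC` differs from compound 3 by 4-methylphenyl in place of 2-(trifluoromethyl)phenyl on a double-bonded chain carbon bound to an aromatic carbon. Among the measured compounds shown here, no measured step exchanges a trifluoromethyl-bearing ring for a methyl-bearing one; the nearest guides are the earlier aryl swaps, a 1.1-fold higher number from compound 1 to compound 3 (0.04 log units; within the scatter) and a 2.3-fold higher number from compound 2 to compound 3 (0.37 log units; beyond the scatter), which were small or within the scatter. A change within the scatter is therefore expected, a 1.0-fold lower number from compound 3 to compound 4 (0.01 log units; within the scatter). Compound 4 is estimated at 5000 nM, within a range from 2000 nM to 12000 nM.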

Compound 4, half-maximal inhibitory concentration: "not active" (no number reported)
Compound 4 has no reported number here; the estimate stays without a comparison.
By their numbers in this assay, from the lowest: compound 2; then compounds 1 and 3 (each within the scatter of the next).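

Among the compounds shown here, compound 4 is reported only as "not active", without a number, so no step from compound 3 to compound 4 can be read. From the compounds shown here alone, what 4-methylphenyl does to the number in place of 2-(trifluoromethyl)phenyl stays open. No other data bear on this result.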